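The compounds below may be only part of what the source reports. "The series", "measured", "known", "first", "only" and "open" are said of these compounds alone.

In a functional assay on HL-60 cells (Homo sapiens) for antiproliferative activity, read by MTT assay, with a stated time of 24 h (on this read-out lower numbers stand for stronger inhibition and higher numbers for weaker inhibition), the two measured compounds share one core. Compound 1 `CCCCc1oc2ccccc2c1C(=O)c1ccc(OCC(=O)N2CCOCC2)cc1` gives > 50000 nM, which is a limit of the assay and not a number. Going by the values given here, compound 2 `CCCCc1oc2ccccc2c1C(=O)c1ccc(OCCCC(=O)N2CCCCC2)cc1` gives 31900 nM, the only actual number so far, so its standing can be judged only against (the limit of > 50000 nM in this assay, at which 1 of the 2 values shown sits).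

Compound 3 `CCCCc1oc2ccccc2c1C(=O)c1ccc(OCCCC(=O)N2CCOCC2)cc1` keeps the chain of compound 2 and differs from it at one place, with morpholin-4-yl in place of piperidin-1-yl on a carbonyl carbon. Among the compounds with values here, one measured step bears on this change. The step of an at least 1.5-fold lower number from compound 1 to compound 2 (0.19 log units; that floor lies within the scatter) has a floor that lies within the scatter. That step replaces morpholin-4-yl with piperidin-1-yl but also alters the chain, so it does not isolate the ring exchange.

On the evidence of that step, the reverse ring exchange is expected to bring at most a modest move toward higher numbers in this assay, perhaps none beyond the scatter, and compound 3 may reach the limit of the assay. The expected change is a 1.4-fold higher number from compound 2 to compound 3 (0.15 log units; within the scatter). The estimate for compound 3 is 45000 nM, with an expected range of 25000 nM to 90000 nM.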

Compound 3, half-maximal inhibitory concentration: 34100 nM
For compound 3 the middle estimate is 1.3-fold (0.12 log units) above the measured one; measured number inside the range.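

In this assay, the exchange of piperidin-1-yl for morpholin-4-yl on a carbonyl carbon can now be read on its own, free of the chain change that came with it in the earlier step, and it gives a 1.1-fold higher number from compound 2 to compound 3 (0.03 log units; within the scatter). With morpholin-4-yl held fixed, the chain change can also be read separately, as an at least 1.4-fold lower number from compound 1 to compound 3 (0.16 log units; that floor lies within the scatter), so neither change is shown to move the number beyond the scatter. Compound 1 stands at a limit and not a number, so this chain step is only a floor and its true size stays unknown: the limit of > 50000 nM in this assay, at which 1 of the 3 values shown sits.

The compounds shown leave open whether any other group on this carbonyl carbon, such as an open-chain diethylamino group or the hydroxyl of a free carboxylic acid, would separate from piperidin-1-yl and morpholin-4-yl by more than the scatter. They also leave open how a longer chain between the aromatic oxygen and the carbonyl would read in this assay, since the chain comparison here rests on a single pair.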